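The compounds below may be only part of what the source reports. "The series", "measured", "known", "first", "only" and "open" are said of these compounds alone.

Compound 1 `Cc1cc(C)c(Nc2ccc(Cl)c(Cl)c2)c(C)c1` is one of two compounds with a value in an assay on isolated protein for binding affinity to Rap guanine nucleotide exchange factor 4 (Homo sapiens), read by cAMP accumulation; a higher number here means a weaker inhibitor, a lower number a stronger inhibitor; there compound 1 gives 1100 nM. Compound 2 `Cc1cc(C)c(Nc2ccc(C)c(Cl)c2)c(C)c1`, which carries a methyl in place of chloro on an aromatic carbon, gives 1800 nM in this assay. Compound 1 thus stands at the lowest of the two numbers, but the step of a 1.6-fold higher number from compound 1 to compound 2 (0.21 log units; within the scatter) lies within the scatter, so the two compounds cannot be told apart on this evidence.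

Compound 3 `Cc1cc(C)c(Nc2ccc(Cl)c(C(F)(F)F)c2)c(C)c1` has not yet been measured in this assay. It differs from compound 1 by trifluoromethyl in place of chloro on an aromatic carbon. Going by the values given here, the only measured step that bears on this change is the one from compound 1 to compound 2, where exchanging the chloro on an aromatic carbon ortho to a chloro group for a methyl moved the number by a 1.6-fold higher number from compound 1 to compound 2 (0.21 log units; within the scatter), that is, within the scatter. On that single precedent, exchanging the same chloro for a trifluoromethyl is expected to move the number little in this assay, with a step of a 1.4-fold higher number from compound 1 to compound 3 (0.13 log units; within the scatter) estimated from compound 1 to compound 3. Compound 3 is therefore expected to give about 1500 nM in this assay, within a range from 500 nM to 4500 nM.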

Compound 3, half-maximal inhibitory concentration: 400 nM
Compound 3: middle estimate off by 3.8-fold (0.57 log units), on the high side; measured number outside the range, below it.
By their numbers in this assay, from the lowest: compound 3; then compounds 1 and 2 (each within the scatter of the next).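

Placing trifluoromethyl where the chloro stood, on an aromatic carbon ortho to a chloro group and meta to a large group, gives a 2.8-fold lower number from compound 1 to compound 3 (0.44 log units; beyond the scatter) in this assay, the first step in this small set to lie beyond the scatter. It shows that the number responds to what this place carries, and that a group of 4 heavy atoms in place of a single chlorine is accepted there with a stronger inhibitor as the outcome, something the earlier step, a 1.6-fold higher number from compound 1 to compound 2 (0.21 log units; within the scatter), could not show because it stayed within the scatter. Nothing measured on these compounds accounts for the gain, so the reason for it remains unknown.

With only one replacement giving a step beyond the scatter, the compounds shown leave open whether the lower number belongs to trifluoromethyl alone or would also come with a bromine, a nitrile or a methoxy group at the same place. They also leave open whether an amine or a carboxylic acid would be accepted there, and whether a trifluoromethyl in place of the remaining chloro would give a similar step.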